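A few compounds are considered here, and "the series" means these few. Any claim that something is new, unique, unknown or untested is made for them only; others in the source may bear on it.

Notes on the series. Compound 3 `CCn1cc(C(=O)C(=O)Nc2ccncc2)c2ccccc21` in a functional assay on FaDu cells (Homo sapiens) for cytotoxicity, read by MTT assay, with a stated time of 72 h (on this read-out lower numbers stand for higher toxicity in this test and higher numbers for lower toxicity in this test), returns only the limit > 10000 nM, which is a limit of the assay and not a number. Compound 1 `CCn1cc(C(=O)C(=O)Nc2ccnc(OC)c2)c2ccccc21` differs from compound 3 by methoxy in place of hydrogen on an aromatic carbon; in this assay compound 1 gives 4180 nM, a step of an at least 2.3-fold lower number from compound 3 to compound 1 (0.37 log units; beyond the scatter). Compound 2 `COc1ccc(NC(=O)C(=O)c2cn(C(C)C)c3ccccc23)cc1` carries another core; how its core differs from that of compound 3 is not broken down here. In this assay compound 2 gives 181 nM, the lowest of the two numbers, with compound 1 as the nearest measured value. Compound 4 `COc1ccc(NC(=O)C(=O)c2cn(C(C)C)c3ccccc23)cc1OC` differs from compound 2 by methoxy in place of hydrogen on an aromatic carbon. This is the same kind of change as from compound 3 to compound 1, though the place differs: there the methoxy sat on a six-membered aromatic ring with one nitrogen, next to the ring nitrogen, here it sits on a six-membered aromatic ring of carbon only, ortho to a methoxy group. Within the data shown here, the step expected is a 1.5-fold lower number from compound 2 to compound 4 (0.18 log units; within the scatter), which rests on the measured step of an at least 2.3-fold lower number from compound 3 to compound 1 (0.37 log units; beyond the scatter) as the single precedent. Compound 4 is estimated at 120 nM in this assay, between 40 nM and 400 nM.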

Compound 4, concentration lethal to 50% of the cells: > 10000 nM
Compound 4: only a limit was reported; the forecaster's own chance of this, stated with the estimate: 3%; at least 83-fold (1.92 log units) between middle value and limit.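

Methoxy in place of hydrogen on an aromatic carbon gives an at least 55-fold higher number from compound 2 to compound 4 (1.74 log units; beyond the scatter) in this assay, a step that rests on a limit of the assay for compound 4, so its full size stays unknown. The change therefore does not carry over as a constant step from one core to the other in this series: the same change on two cores in this assay, an at least 2.3-fold lower number (0.37 log units; beyond the scatter) from compound 3 to compound 1 and an at least 55-fold higher number (1.74 log units; beyond the scatter) from compound 2 to compound 4, at least 130-fold (2.12 log units) apart, beyond the scatter of two such steps. The two pairs differ in core and also in the place of the methoxy, and they do not show which of these accounts for the gap.

Open, as far as these compounds go, is whether an ethoxy group, a hydroxy group or a fluorine at the same place, ortho to a methoxy group, would behave as methoxy does on compound 4. Also open, from the compounds shown here alone, is how the same change behaves on any further core.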